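The compounds below may be only part of what the source reports. "The series", "measured", "known", "first", "only" and "open" are said of these compounds alone.

Compound 1 `CSc1nc(SC)c2ncn([C@@H]3C[C@@H](O)[C@H](CO)O3)c2n1` and compound 2 `CSc1nc(N(C)C)c2ncn([C@@H]3C[C@@H](O)[C@H](CO)O3)c2n1` share one core and differ at a single aromatic carbon. In a functional assay on MOLT-4 cells (Homo sapiens) (on this read-out higher numbers stand for weaker inhibition and lower numbers for stronger inhibition), compound 1 gives 141 uM, and compound 2 gives 172 uM. The step of a 1.2-fold higher number from compound 1 to compound 2 (0.09 log units; within the scatter) lies within the scatter, so compound 2 stands alongside compound 1 rather than apart from it. Compound 3 `CSc1nc(N)c2ncn([C@@H]3C[C@@H](O)[C@H](CO)O3)c2n1` carries amino in place of dimethylamino on an aromatic carbon. Among the compounds with values here, only that single measured step bears on this change, and it produced no movement beyond the scatter, so no shift is expected in this assay, with an estimated step of a 1.1-fold lower number from compound 2 to compound 3 (0.06 log units; within the scatter). Compound 3 is therefore estimated at 150 uM, with a range from 60 uM to 400 uM.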

Compound 3, concentration for 50% inhibition: > 300 uM
Compound 3: only a limit was reported; the forecaster's own chance of this, stated with the estimate: 10%; middle value at least 2.0-fold (0.30 log units) away from the limit.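

Compound 3 is read only as a limit, not as a number: the limit of > 300 uM in this assay, at which 1 of the 3 values shown sits. Within the data shown here, at this aromatic carbon, amino gives the first step that clears the scatter, an at least 2.1-fold higher number from compound 1 to compound 3 (0.32 log units; beyond the scatter), whereas methylsulfanyl and dimethylamino had stood alongside each other. Against dimethylamino the step is an at least 1.7-fold higher number from compound 2 to compound 3 (0.24 log units; that floor lies within the scatter), so this floor alone does not set amino apart from dimethylamino.

As far as these compounds go, how far compound 3 lies past its limit stays open, and with it the full size of both steps. Also open, from the compounds shown here alone, is how a hydroxyl, a methoxy group or a longer amine would read at this carbon.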